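Isopropyl to Trifluoromethyl: A Small Change Weighed

The source may hold more compounds than are shown below. What is called first, only, known or untested is meant among the compounds shown, and "the series" means these compounds.

Compound 1, `CCCCCc1c(C(C)C)nc(C(C)C)c(CO)c1-c1ccc(O)cc1`, gives 24% in an assay on CHO cells for inhibition of Glucagon receptor (Homo sapiens), tested at 20 uM; on this read-out higher numbers stand for more inhibition at the one concentration tested (going by the name of the read-out) and lower numbers for less inhibition.
Compound 2, `CCCCCc1c(C(C)C)nc(C(C)C)c(CO)c1-c1ccc(C(C)C)cc1`, gives 34% in this assay.

Of these two measured compounds, compound 2 shows the higher number in this assay, with compound 1 nearest. Within the data shown here, the one measured step, a number 10 percentage points higher from compound 1 to compound 2 (within the scatter), replaced hydroxy with isopropyl on an aromatic carbon and stays within the usual scatter, so the two compounds cannot be ranked against each other.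

Compound 3, `CCCCCc1c(C(C)C)nc(C(C)C)c(CO)c1-c1ccc(C(F)(F)F)cc1`, has not yet been measured. It differs from compound 2 in one place: trifluoromethyl in place of isopropyl on an aromatic carbon. Among the measured compounds shown here, no measured step compares a trifluoromethyl with an isopropyl, and the only step known concerns a different group and was itself within the scatter. Nothing in the data therefore points to a shift beyond the scatter.

Compound 3 is expected to give 32% in this assay, with a range from 15% to 50%. The expected step is a number 2 percentage points lower from compound 2 to compound 3 (within the scatter), one that stays within the scatter.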

Compound 3, a percentage reported as inhibition, at one concentration (the size of the read-out at that concentration, not a potency): 35%
Compound 3: the middle estimate sits 3 percentage points below what was measured, within the range that was stated.
By their numbers in this assay, from the lowest: compounds 1, 2 and 3 (each within the scatter of the next, the first and the last beyond it).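

In this assay, putting trifluoromethyl in place of isopropyl on this aromatic carbon gives a number 1 percentage points higher from compound 2 to compound 3 (within the scatter), so these two groups cannot be told apart here. Trifluoromethyl in place of hydroxy gives a number 11 percentage points higher from compound 1 to compound 3 (beyond the scatter), the first step at this position to clear the scatter, although a modest one, while compound 2 remains within the scatter of both compound 1 and compound 3. No measurement available here bears on the reason for these results.

Still open, on these data alone, is how an amine, a carboxylic acid or a longer chain would read at this same position. As far as these compounds go, with each number taken at a single concentration, how the compounds compare in potency also remains open.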